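Notes on amide and phenol variation in a small set

A few compounds are considered here, and "the series" means these few. Any claim that something is new, unique, unknown or untested is made for them only; others in the source may bear on it.

The measured compounds are compound 1 `COc1ccc2c(=O)c(/C=C/C(=O)NCc3ccc(C)cc3)coc2c1`, compound 2 `Cc1ccccc1NC(=O)/C=C/c1coc2cc(O)ccc2c1=O` and compound 3 `COc1ccc2c(=O)c(/C=C/C(=O)Nc3ccccc3C)coc2c1`; compound 4 `Cc1ccc(CNC(=O)/C=C/c2coc3cc(O)ccc3c2=O)cc1` has not yet been measured. In a functional assay on L02 cells (Homo sapiens) for inhibition, read by MTT assay, with a stated time of 48 h (on this read-out higher numbers stand for weaker inhibition and lower numbers for stronger inhibition), compound 1 gives > 200000 nM, which is a limit of the assay and not a number. In this assay compound 2 gives > 200000 nM, again a limit. In this assay compound 3 gives > 200000 nM, also a limit. Compound 3 and compound 1 differ as 4-methylbenzyl in place of 2-methylphenyl on an amide-type nitrogen, and the step that the two limits leave unreadable from compound 3 to compound 1 cannot be sized. Compound 3 and compound 2 differ as hydrogen in place of methyl on an oxygen on an aromatic ring, and the step that the two limits leave unreadable from compound 2 to compound 3 is likewise unreadable because every value sits at the limit of > 200000 nM in this assay, at which 3 of the 3 values shown sit. Compound 2 and compound 4 differ as 4-methylbenzyl in place of 2-methylphenyl on an amide-type nitrogen, the same change as that made from compound 3 to compound 1. The step from compound 2 to compound 4 is expected to be a number no higher from compound 2 to compound 4 (the limit leaves the size open), resting on the unreadable step that the two limits leave unreadable from compound 3 to compound 1. Compound 4 is expected at 200000 nM, between 80000 nM and 500000 nM, and most probably reported only as a limit.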

Compound 4, half-maximal inhibitory concentration: > 200000 nM
Compound 4: no number, only a limit (the forecaster's own chance of this, stated with the estimate: 85%); the middle value lies on the limit itself.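

In this assay compound 4 gives > 200000 nM as well, which is a limit and not a number. No new step can be read between compound 4 and either compound 1 or compound 2, because the values all rest on one limit: the limit of > 200000 nM in this assay, at which 4 of the 4 values shown sit.

The compounds shown leave open whether either change, on the amide-type nitrogen or on the oxygen, alters inhibition at all.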